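The source may hold more compounds than are shown below. What is called first, only, known or untested is meant among the compounds shown, and "the series" means these compounds.

Compound 1 `CCCCCCCCCCCC(=O)NCC(=O)N[C@@H]1[C@@H](O)[C@H](O)[C@@H](Nc2ncnc3[nH]cnc23)O[C@H]1C` gives > 10000 nM in a functional assay on L1210 cells (Mus musculus) for cytotoxicity; a lower number here means a stronger inhibitor, a higher number a weaker inhibitor; this is a limit of the measurement, not a number.
Compound 2 `CCOCCC(=O)NCC(=O)N[C@@H]1[C@@H](O)[C@H](O)[C@@H](Nc2ncnc3[nH]cnc23)O[C@H]1C` gives > 500000 nM in this assay, again a limit.
Compound 3 `CCOCCC(=O)NCC(=O)N[C@@H]1[C@@H](O)[C@H](O)[C@@H](Nc2ncnc3[nH]cnc23)O[C@H]1CO` gives > 500000 nM in this assay, also a limit.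

Compound 2 thus stands at the limit of > 500000 nM in this assay, at which 2 of the 3 values shown sit, with no true number to anchor it, and the other two values shown are limits as well. Compound 4 `CCCCCC(=O)NCC(=O)N[C@@H]1[C@@H](O)[C@H](O)[C@@H](Nc2ncnc3[nH]cnc23)O[C@H]1C` is still to be measured; the change from compound 2 is propyl in place of ethoxy on a saturated chain carbon, two bonds along the chain from a carbonyl carbon. The two measured steps, a step that the two limits leave unreadable from compound 1 to compound 2 and a step that the two limits leave unreadable from compound 2 to compound 3, bear on this change, but neither has a readable size, so no direction in this assay can be read from them. Compound 4 is therefore expected to remain weak, near 300000 nM, between 30000 nM and 1000000 nM. That would amount to an expected step of an at least 1.6-fold lower number from compound 2 to compound 4 (0.22 log units; that floor lies within the scatter).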

Compound 4, half-maximal inhibitory concentration: 250000 nM
Estimate against measurement, compound 4: 1.2-fold (0.08 log units) above, and the stated range covers the measured number.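

Among these compounds, compound 4 is the first compound here with a true number rather than a limit, which gives this position an anchor in this assay. Propyl in place of ethoxy gives an at least 2.0-fold lower number from compound 2 to compound 4 (0.30 log units; that floor lies within the scatter), so no real change is established. That step has only a floor because compound 2 sits at a limit: the limit of > 500000 nM in this assay, at which 2 of the 4 values shown sit.

As far as these compounds go, the step from compound 1 to compound 4 cannot be read, so what a longer chain does stays open. Also open, from the compounds shown here alone, is how an amine or a carboxylic acid in place of propyl would behave in this assay.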